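This account rests on a few compounds, and the source may have more. Where it says the series, first, only, none or still open, it means among the compounds named here.

Compounds measured so far in an ADME assay on Vero cells (Chlorocebus sabaeus) for cytotoxicity, read by MTT assay, with a stated time of 72 h; on this read-out higher numbers stand for lower toxicity in this test and lower numbers for higher toxicity in this test:
compound 1 `COC(=O)c1cc(-c2cccc(NC(=O)c3ccc(/C=C/C(=O)c4ccc(OC)cc4OC)cc3)c2)on1`: > 50 ug/mL
compound 2 `CCCOc1ccc(C(=O)/C=C/c2ccc(C(=O)O)cc2)cc1`: < 10 ug/mL
compound 3 `CCOC(=O)c1cc(-c2cccc(NC(=O)c3cccc(C(F)(F)F)c3)c2)on1`: "not determined" (no result reported)

Compound 1 sits at a limit of this assay rather than at a number, its value of > 50 ug/mL being the upper bound reported, as noted in the limit of > 50 ug/mL in this assay, at which 1 of the 3 values shown sits. Compound 2 likewise sits at a limit, its value of < 10 ug/mL being the lower bound, as noted in the limit of < 10 ug/mL in this assay, at which 1 of the 3 values shown sits. For compound 3 the reading in this assay is "not determined" (no result reported), so no figure is available. Going by the values given here, no step between two measured compounds that differ in one place is available, and nothing links the three beyond what their own values show.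

Compound 4 `COC(=O)c1cc(-c2cccc(NC(=O)c3ccc(/C=C/C(=O)c4ccc(OC)c(OC)c4)cc3)c2)on1` shares all its atoms with compound 1, joined differently: 3,4-dimethoxyphenyl in place of 2,4-dimethoxyphenyl on a carbonyl carbon. Among the compounds with values here, with compound 1 reported only as a limit and no measured step to lean on, the expected change is none beyond the scatter. Compound 4 is therefore estimated at 55 ug/mL (range 25 ug/mL to 120 ug/mL), a step that the limit leaves unreadable from compound 1 to compound 4 that is expected to be within scatter.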

Compound 4, half-maximal cytotoxic concentration: > 50 ug/mL
Compound 4: only a limit was reported (the forecaster's own chance of this, stated with the estimate: 70%); the middle value does not contradict the limit.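

No step from compound 1 to compound 4 can be read in this assay, since both compounds are reported only as a limit: the limit of > 50 ug/mL in this assay, at which 2 of the 4 values shown sit.

The compounds shown leave open whether 3,4-dimethoxyphenyl in place of 2,4-dimethoxyphenyl changes the result in this assay at all.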